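Changing the Ring on the Carbonyl Carbon: Compound 4

This account rests on a few compounds, and the source may have more. Where it says the series, first, only, none or still open, it means among the compounds named here.

Three compounds built on one shared core differ only in the aromatic ring attached to a carbonyl carbon. Compound 1 `CN(C)C(=S)SCC(CSC(=S)N(C)C)C(=O)c1ccc(F)cc1` gives 1210 nM in a functional assay on NCI-H460 cells (Homo sapiens) for inhibition, read by MTT assay, with a stated time of 72 h; on this read-out higher numbers stand for weaker inhibition and lower numbers for stronger inhibition. Compound 2 `COc1cccc(C(=O)C(CSC(=S)N(C)C)CSC(=S)N(C)C)c1` gives 1240 nM in this assay. Compound 3 `CN(C)C(=S)SCC(CSC(=S)N(C)C)C(=O)c1cccnc1` gives 870 nM in this assay, the lowest of the three numbers, although its gaps to the other two fall within the scatter of repeated measurements, so no order among them can be claimed.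

Compound 4 `CN(C)C(=S)SCC(CSC(=S)N(C)C)C(=O)c1ccc[nH]1` has not yet been measured. It differs from compound 3 in one place: 1H-pyrrol-2-yl in place of pyridin-3-yl on a carbonyl carbon. The measured steps that bear on this change are the ones that also exchange the ring on the carbonyl carbon: a 1.0-fold higher number from compound 1 to compound 2 (0.01 log units; within the scatter), a 1.4-fold lower number from compound 1 to compound 3 (0.14 log units; within the scatter) and a 1.4-fold lower number from compound 2 to compound 3 (0.15 log units; within the scatter). Each of these lies within the scatter, so exchanging the ring at this position has so far hardly moved the number. Among the compounds with values here, no measured step involves a five-membered ring or a ring with a hydrogen-bond donor, so the expectation rests only on three different rings having given similar numbers. Compound 4 is therefore expected to show no step beyond the scatter, namely a 1.1-fold higher number from compound 3 to compound 4 (0.04 log units; within the scatter). The estimate for compound 4 is 950 nM, with an expected range from 400 nM to 2300 nM.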

Compound 4, half-maximal inhibitory concentration: 97300 nM
Estimate against measurement, compound 4: 100-fold (2.01 log units) below, and the stated range ends below it.
By their numbers in this assay, from the lowest: compounds 3, 1 and 2 (each within the scatter of the next); then compound 4.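

In this assay the ring on the carbonyl carbon turns out not to be freely exchangeable: 1H-pyrrol-2-yl in place of pyridin-3-yl gives a 110-fold higher number from compound 3 to compound 4 (2.05 log units; beyond the scatter) and so marks much weaker inhibition, in place of 3-methoxyphenyl it gives a 78-fold higher number from compound 2 to compound 4 (1.89 log units; beyond the scatter) and in place of 4-fluorophenyl it gives an 80-fold higher number from compound 1 to compound 4 (1.91 log units; beyond the scatter) on the same shared core. The three earlier rings gave numbers within the scatter of one another, so only compound 4 reveals that this position can respond strongly to a single exchange. Unlike pyridin-3-yl, the entering ring is five-membered and carries a hydrogen-bond donor but no hydrogen-bond acceptor, yet no measurement shown explains the large step.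

The compounds shown do not separate the effect of the smaller ring from that of the hydrogen on its nitrogen, as compound 4 changes both in one exchange. A methyl group in place of that hydrogen on the 1H-pyrrol-2-yl ring would test whether the number returns toward those of the other compounds or stays high.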